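This account rests on a few compounds, and the source may have more. Where it says the series, first, only, none or still open, it means among the compounds named here.

Among the measured compounds shown here, compound 1 `COc1ccc(CN(C(=O)CSC(=S)N2CCN(C(=O)OC(C)(C)C)CC2)c2cc(OC)c(OC)c(OC)c2)cc1` is the only member of this small set with a measured number: in a functional assay on MGC-803 cells (Homo sapiens) for inhibition, read by CCK-8 assay, with a stated time of 48 h (on this read-out lower numbers stand for stronger inhibition and higher numbers for weaker inhibition), compound 1 gives 310 nM. Compound 2 `COc1ccc(CN(C(=O)CSC(=S)N2CCN(C(=O)OC(C)(C)C)CC2)c2ccc(Cl)cc2)cc1` carries 4-chlorophenyl in place of 3,4,5-trimethoxyphenyl on an amide-type nitrogen. For compound 2 this assay reports only a limit, > 20000 nM, and not a number. The resulting step is an at least 64-fold higher number from compound 1 to compound 2 (1.80 log units; beyond the scatter), and it rests on (the limit of > 20000 nM in this assay, at which 1 of the 2 values shown sits).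

Compound 3 `COc1ccc(CN(C(=O)CSC(=S)N2CCN(C(=O)OC(C)(C)C)CC2)c2cc(OC)c(OC)c(OC)c2)cc1O` differs from compound 1 elsewhere in the molecule: hydroxy in place of hydrogen on an aromatic carbon. For the measured compounds named here, the single measured step swapped 3,4,5-trimethoxyphenyl for 4-chlorophenyl on the amide-type nitrogen, whereas this change turns 4-methoxybenzyl into 3-hydroxy-4-methoxybenzyl, so that step offers little guidance here. Going by the values given here, with no measured step at this position, the expectation is a change that stays near or within the usual scatter, in either direction. Compound 3 is therefore estimated at 400 nM in this assay, with a likely range from 150 nM to 1500 nM. This estimate corresponds to an expected step of a 1.3-fold higher number from compound 1 to compound 3 (0.11 log units; within the scatter).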

Compound 3, half-maximal inhibitory concentration: 82 nM
Beside the measured number, compound 3's estimate is 4.9-fold (0.69 log units) above it; the measured number lies below the stated range.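

The 4-methoxybenzyl group is not a silent part of the molecule: in this assay, turning it into 3-hydroxy-4-methoxybenzyl gives a 3.8-fold lower number from compound 1 to compound 3 (0.58 log units; beyond the scatter) on a change of a single heavy atom. Among the compounds shown here, the only earlier step lay on the amide-type nitrogen, so this is the first measured sign that the other aromatic ring can also shift the number, and here the shift is towards stronger inhibition. Nothing measured in the compounds shown bears on why this step occurs.

The compounds shown leave open whether the gain belongs to the hydroxy itself or could also come from another group at this place, such as an amine, a carboxylic acid or a hydroxymethyl group, on the same aromatic carbon. Also open, going by these compounds, is whether the same hydroxy would change the number in a similar way with 4-chlorophenyl on the amide-type nitrogen, or whether its effect is tied to the 3,4,5-trimethoxyphenyl group.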